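From 3-chlorophenyl to benzyl on a shared core

The compounds below may be only part of what the source reports. "The series", "measured", "known", "first", "only" and "open" are said of these compounds alone.

Of the compounds shown here, three with the same core have been measured in a functional assay on T98G cells (Homo sapiens) for inhibition, read by MTT assay, with a stated time of 72 h; on this read-out lower numbers stand for stronger inhibition and higher numbers for weaker inhibition. Compound 1 `COc1ccc(NC(=S)NC2CC(C)(C)Oc3ccc(Br)cc32)cc1` gives 33000 nM. Compound 2 `CC1(C)CC(NC(=S)Nc2cccc(C#N)c2)c2cc(Br)ccc2O1` gives 9000 nM. Compound 3 `CC1(C)CC(NC(=S)Nc2cccc(Cl)c2)c2cc(Br)ccc2O1` gives 9000 nM, so it shares the lowest number of the three with compound 2.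

Compound 4 `CC1(C)CC(NC(=S)NCc2ccccc2)c2cc(Br)ccc2O1` has benzyl in place of 3-chlorophenyl on an amide-type nitrogen. Within the data shown here, no measured step makes this exact swap, so the nearest guides are changes at the same nitrogen. Moving from 4-methoxyphenyl gave a 3.7-fold lower number from compound 1 to compound 2 (0.56 log units; beyond the scatter) and a 3.7-fold lower number from compound 1 to compound 3 (0.56 log units; beyond the scatter), both modest. Swapping chloro and cyano on the ring gave no change at the digits printed from compound 2 to compound 3 (within the scatter). Changes at this nitrogen have therefore moved the number only modestly so far, and compound 3 already sits at the low end. The expected change is a 1.7-fold higher number from compound 3 to compound 4 (0.22 log units; within the scatter), a modest one towards weaker inhibition. The estimated value for compound 4 is 15000 nM, with an expected range from 6000 nM to 40000 nM.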

Compound 4, half-maximal inhibitory concentration: 54000 nM
The estimate for compound 4 lay 3.6-fold (0.56 log units) below the measured number; the whole stated range lies below it.
By their numbers in this assay, from the lowest: compounds 2 and 3 (each within the scatter of the next); then compounds 1 and 4 (each within the scatter of the next).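

Benzyl and 3-chlorophenyl have the same heavy-atom count and each holds one six-membered aromatic ring, yet this swap gives a 6.0-fold higher number from compound 3 to compound 4 (0.78 log units; beyond the scatter). Replacing 3-cyanophenyl with benzyl gives a matching result, a 6.0-fold higher number from compound 2 to compound 4 (0.78 log units; beyond the scatter), so this nitrogen tells apart groups that those counts do not separate. Replacing 4-methoxyphenyl with benzyl gives a 1.6-fold higher number from compound 1 to compound 4 (0.21 log units; within the scatter), which places compound 4 with compound 1 and apart from compounds 2 and 3, and nothing measured here gives a reason for this split.

The compounds shown leave open whether the weaker inhibition comes with benzyl itself or with the loss of the chloro group. Unsubstituted phenyl and 3-chlorobenzyl on this nitrogen would separate those two readings, and a longer chain such as 2-phenylethyl would extend the comparison.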